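Shortening the Hydroxamate Chain by One Unit

A few compounds are considered here, and "the series" means these few. Any claim that something is new, unique, unknown or untested is made for them only; others in the source may bear on it.

Compound 1 (`CC(C)c1cc(-c2n[nH]c(=O)n2-c2cccc(C(=O)NCCCC(=O)NO)c2)c(O)cc1O`) : 4600 nM
Compound 2 (`CC(C)c1cc(-c2n[nH]c(=O)n2-c2ccc(C(=O)NCCCCCCC(=O)NO)cc2)c(O)cc1O`) : 4600 nM

In a functional assay on A549 cells (Homo sapiens) for inhibition (on this read-out higher numbers stand for weaker inhibition and lower numbers for stronger inhibition), compound 2 stands at (4600 nM), level with compound 1 (4600 nM) and so within the usual scatter. Compound 3 (`CC(C)c1cc(-c2n[nH]c(=O)n2-c2ccc(C(=O)NCCCCCC(=O)NO)cc2)c(O)cc1O`) has yet to be measured. It differs from compound 2 in one place only, with hydroxycarbamoyl in place of (hydroxycarbamoyl)methyl on a saturated chain carbon, five bonds along the chain from an amide-type nitrogen. Cut one bond further out, the same difference reads 4-(hydroxycarbamoyl)butyl to 3-(hydroxycarbamoyl)propyl. Among the measured compounds shown here, no measured pair isolates this change, so the data hold no direct step for it. Compound 1 (4600 nM) and compound 2 (4600 nM) differ in more than one place, the chain among them, and their two values are the same at the digits shown. On that slim evidence, no step beyond the scatter is expected in this assay and neither direction is favoured. The expected step is small (a 1.0-fold lower number from compound 2 to compound 3 (0.01 log units; within the scatter)). The estimate for compound 3 is (4500 nM), with an expected range from (2000 nM) to (10000 nM).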

Compound 3, half-maximal inhibitory concentration: 4600 nM
Compound 3: the middle estimate sits 1.0-fold (0.01 log units) below what was measured; low and high end bracket the measured number.
By their numbers in this assay, from the lowest: compounds 1, 2 and 3 (each within the scatter of the next).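

In this assay the change from 4-(hydroxycarbamoyl)butyl to 3-(hydroxycarbamoyl)propyl now has a direct reading, with no change at the digits printed from compound 2 to compound 3 (within the scatter) in a pair that differs in one place only, which compound 1 and compound 2 could not offer. On a saturated chain carbon, five bonds along the chain from an amide-type nitrogen, hydroxycarbamoyl can therefore take the place of (hydroxycarbamoyl)methyl without a step that stands out from the scatter of this read-out. The data given offer no explanation for this flat result.

This is a single step in one cell assay, so it leaves open whether the read-out would also stay level with a longer chain or with a chain cut back further on the same core. Going by these compounds, it is equally open whether replacing the terminal hydroxycarbamoyl with a carboxylic acid or an amine at this position would move the number beyond the scatter.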